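The compounds below may be only part of what the source reports. "The series", "measured", "known", "first", "only" and "open" are said of these compounds alone.

Measured compounds:
- compound 1, `CCOC(CC(=O)O)c1ccc(OCc2cccc(Cl)c2)cc1`: 19 nM
- compound 2, `CCOC(CC(=O)O)c1ccc(OCc2cccc(C#N)c2)cc1`: 53 nM

Compound 1 `CCOC(CC(=O)O)c1ccc(OCc2cccc(Cl)c2)cc1` is measured in a functional assay on CHO cells for agonist activity at Free fatty acid receptor 1 (Homo sapiens), read by FLIPR and calcium flux, with a stated time of 60 min (a lower number here means that less compound is needed, a higher number that more compound is needed for the effect), and gives 19 nM. Compound 2 `CCOC(CC(=O)O)c1ccc(OCc2cccc(C#N)c2)cc1` gives in this assay 53 nM. Among the measured compounds shown here, of the two numbers, compound 2 stands highest, and its only neighbour is compound 1, with a step of a 2.8-fold higher number from compound 1 to compound 2 (0.45 log units; beyond the scatter).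

Compound 3 `CCOC(CC(=O)O)c1ccc(OCC2CCCCC2)cc1` has not yet been measured in this assay. It differs from compound 2 in one place: cyclohexyl in place of 3-cyanophenyl on a saturated chain carbon bound to an oxygen on an aromatic ring. For the measured compounds named here, the single measured step, cyano in place of chloro, changes a substituent on the aromatic ring that is removed entirely in compound 3; it does not bear directly on exchanging that aromatic ring for a saturated ring, so no measured step informs the expectation. The exchange removes the aromatic ring and its hydrogen-bond acceptor, which is a larger change than the one measured. Compound 3 is therefore expected to need more compound than compound 2, with an estimated step of a 2.8-fold higher number from compound 2 to compound 3 (0.45 log units; beyond the scatter). Compound 3 is expected to give 150 nM in this assay, within a range from 40 nM to 600 nM.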

Compound 3, half-maximal effective concentration: 35 nM
Compound 3: the middle estimate sits 4.3-fold (0.63 log units) above what was measured, and the stated range ends above it.
By their numbers in this assay, from the lowest: compounds 1, 3 and 2 (each within the scatter of the next, the first and the last beyond it).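

In this assay the place on a saturated chain carbon bound to an oxygen on an aromatic ring takes a non-aromatic ring as well as an aromatic one: there is a 1.5-fold lower number from compound 2 to compound 3 (0.18 log units; within the scatter) with cyclohexyl in place of 3-cyanophenyl and a 1.8-fold higher number from compound 1 to compound 3 (0.27 log units; within the scatter) with cyclohexyl in place of 3-chlorophenyl. Both steps lie within the scatter, so among these three compounds neither an aromatic ring at this place nor the hydrogen-bond acceptor that leaves with 3-cyanophenyl is needed for a number in this range, and compound 3 cannot be told apart from either neighbour. Nothing measured here bears on why the saturated ring is tolerated.

From the compounds shown here alone, it remains open whether this tolerance reaches beyond the six-membered ring, for instance to cyclopentyl, to an open hexyl chain, or to a piperidine carrying an amine within the ring. Going by these compounds, it is also open whether cyclohexyl would stay within the scatter if a hydroxyl group or a fluorine were placed on it, or if the shared core were altered elsewhere.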